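Halogen change on the aryl ether of compound 2

The source may hold more compounds than are shown below. What is called first, only, known or untested is meant among the compounds shown, and "the series" means these compounds.

Measured compounds:
compound 1 `CC(=O)Nc1cc(-c2cc(F)c(OC[C@@H](N)CC(C)C)c(F)c2)ccn1`: 27 nM
compound 2 `CC(=O)Nc1cc(-c2ccc(OC[C@@H](N)CC(C)C)c(F)c2)ccn1`: 0.52 nM

In an assay on brain (strain C57BL6) for displacement of a labelled ligand from AP2-associated protein kinase 1 (Mus musculus), read by scintillation counting, with a stated time of 1 h (on this read-out lower numbers stand for stronger inhibition and higher numbers for weaker inhibition), compound 2 gives 0.52 nM, the lowest of the two numbers; compound 1 gives 27 nM. Among the compounds with values here, the single measured step is a 52-fold lower number from compound 1 to compound 2 (1.72 log units; beyond the scatter). Compound 3 `CC(=O)Nc1cc(-c2ccc(OC[C@@H](N)CC(C)C)c(Cl)c2)ccn1` differs from compound 2 by chloro in place of fluoro on an aromatic carbon. Within the data shown here, that step concerns removal of a fluoro, not its replacement by another halogen, so no measured step sets the size of this change. A step of a 1.9-fold higher number from compound 2 to compound 3 (0.28 log units; within the scatter) is expected, within the scatter or only slightly toward a higher number. Compound 3 is estimated at 1 nM, with a range from 0.2 nM to 5 nM.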

Compound 3, inhibition constant: 0.06 nM
Compound 3: the middle estimate sits 17-fold (1.22 log units) above what was measured; measured number outside the range, below it.
By their numbers in this assay, from the lowest: compound 3; then compound 2; then compound 1.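

In this assay, the position ortho to the (2-amino-4-methylpentyl)oxy group proves sensitive to the identity of its halogen, with chloro in place of fluoro giving an 8.7-fold lower number from compound 2 to compound 3 (0.94 log units; beyond the scatter). Within the data shown here, the earlier step, a 52-fold lower number from compound 1 to compound 2 (1.72 log units; beyond the scatter), covered only the loss of a fluoro, so this is the first measured exchange of one halogen for another. Nothing on hand accounts for the difference between chloro and fluoro here.

Open, as far as these compounds go, is how bromo, methyl or trifluoromethyl would read at this position. Also open, from the compounds shown here alone, is whether a second fluoro costs as much alongside chloro as it does alongside fluoro.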